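From trifluoromethyl to phenoxy on an aromatic carbon

This account rests on a few compounds, and the source may have more. Where it says the series, first, only, none or still open, it means among the compounds named here.

Measured in a functional assay on HeLa cells (Homo sapiens) for inhibition, read by CCK-8 assay, with a stated time of 72 h; on this read-out higher numbers stand for weaker inhibition and lower numbers for stronger inhibition:
- compound 1 `O=C(/C=C/c1cccnc1)NCCCCCCc1cccc(S(=O)(=O)Nc2ccc(Cl)cc2)c1`: 170 nM
- compound 2 `O=C(/C=C/c1cccnc1)NCCCCCCc1cccc(S(=O)(=O)Nc2ccc(C(F)(F)F)cc2)c1`: 1450 nM

Compound 2, at 1450 nM, holds the higher of the two numbers, so it is the weaker inhibitor of the pair. Compound 3 `O=C(/C=C/c1cccnc1)NCCCCCCc1cccc(S(=O)(=O)Nc2ccc(Oc3ccccc3)cc2)c1` carries a new group at the same place: phenoxy in place of trifluoromethyl on an aromatic carbon. Within the data shown here, one measured step bears on this place, an 8.5-fold higher number from compound 1 to compound 2 (0.93 log units; beyond the scatter). Among the measured compounds shown here, it shows that a swap here can move the number beyond the scatter, but no measured compound has phenoxy, so it gives little guide to direction. The expected change is small, within the scatter: a 1.5-fold lower number from compound 2 to compound 3 (0.16 log units; within the scatter). For compound 3 the estimated value is 1000 nM, with an expected range of 200 nM to 5000 nM.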

Compound 3, half-maximal inhibitory concentration: 262 nM
For compound 3 the middle estimate is 3.8-fold (0.58 log units) above the measured one; measured number inside the range.
By their numbers in this assay, from the lowest: compounds 1 and 3 (each within the scatter of the next); then compound 2.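

In this assay phenoxy at this position gives a 5.5-fold lower number from compound 2 to compound 3 (0.74 log units; beyond the scatter) and so the rise seen with trifluoromethyl does not simply continue as the group gains heavy atoms. Measured against chloro, the same change gives a 1.5-fold higher number from compound 1 to compound 3 (0.19 log units; within the scatter) and shows that a group carrying an aromatic ring is accommodated here without a loss beyond the scatter. No evidence is available to explain why trifluoromethyl stands apart from the other two groups. The compounds shown leave open how an amine or a carboxylic acid would read at this position.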